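This account rests on a few compounds, and the source may have more. Where it says the series, first, only, none or still open, it means among the compounds named here.

Series notes. Compound 1 `CCOc1nc(-c2ccc(NS(=O)(=O)c3cc(Cl)ccc3F)cc2)nc2[nH]nc(C)c12` gives 183 nM in an assay for inhibition of serine/threonine-protein kinase Sgk1 (Homo sapiens), with stated times of 30 min and 60 min, in the presence of a further agent that is not named here; on this read-out higher numbers stand for weaker inhibition and lower numbers for stronger inhibition. Compound 2 `Cc1n[nH]c2nc(-c3ccc(NS(=O)(=O)c4cc(Cl)ccc4F)cc3)nc(OCCC(=O)N(C)C)c12` gives 438 nM in this assay, and compound 3 `Cc1n[nH]c2nc(-c3ccc(NS(=O)(=O)c4cc(Cl)ccc4F)cc3)nc(OC3CCOCC3)c12` gives 14 nM in this assay. Compound 3 carries the lowest number of the three: a 13-fold lower number from compound 1 to compound 3 (1.12 log units; beyond the scatter), and a 31-fold lower number from compound 2 to compound 3 (1.50 log units; beyond the scatter). Between the two chain-bearing compounds, a 2.4-fold higher number from compound 1 to compound 2 (0.38 log units; beyond the scatter).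

Compound 4 `Cc1n[nH]c2nc(-c3ccc(NS(=O)(=O)c4cc(Cl)ccc4F)cc3)nc(OC3CCC(=O)CC3)c12` differs from compound 3 by 4-oxocyclohexyl in place of oxan-4-yl on an oxygen on an aromatic ring. Among the measured compounds shown here, the measured steps that touch this same oxygen, a 13-fold lower number from compound 1 to compound 3 (1.12 log units; beyond the scatter) and a 31-fold lower number from compound 2 to compound 3 (1.50 log units; beyond the scatter), are both large, but each exchanges an open chain for the six-membered ring; no measured step exchanges one six-membered ring for another. The change from compound 3 to compound 4 keeps a six-membered ring on that oxygen, so a step of the large kind is not expected in this assay; a small loss toward compound 1, possibly within the scatter, is the more likely reading. Compound 4 is therefore expected near 30 nM, with a range from 10 nM to 90 nM. That estimate would mean a 2.1-fold higher number from compound 3 to compound 4 (0.33 log units; beyond the scatter).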

Compound 4, half-maximal inhibitory concentration: 18 nM
Compound 4: the middle estimate sits 1.7-fold (0.22 log units) above what was measured; low and high end bracket the measured number.
By their numbers in this assay, from the lowest: compounds 3 and 4 (each within the scatter of the next); then compound 1; then compound 2.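

Within this assay, the first exchange of one six-membered ring for another on this oxygen gives (a 1.3-fold higher number from compound 3 to compound 4 (0.11 log units; within the scatter)) and so does not separate oxan-4-yl from 4-oxocyclohexyl. The ring oxygen of oxan-4-yl is therefore not needed to hold the number here, since the carbon-only ring with its carbonyl keeps the large gaps to the open chains: a 10-fold lower number from compound 1 to compound 4 (1.01 log units; beyond the scatter) against ethyl, and a 24-fold lower number from compound 2 to compound 4 (1.39 log units; beyond the scatter) against 2-(dimethylcarbamoyl)ethyl. No supporting measurement bears on why these two rings read alike.

Still open, going by these compounds, is whether any oxygen on the ring matters, which plain cyclohexyl, 4-hydroxycyclohexyl or a piperidin-4-yl amine on the same oxygen would test. Also open, on these data alone, is whether the ring itself or only branching at the attached carbon carries the gain, which isopropyl and cyclopentyl would separate.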